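Moving the Fluorine: 2-Fluorophenyl to 4-Fluorophenyl

This account rests on a few compounds, and the source may have more. Where it says the series, first, only, none or still open, it means among the compounds named here.

In a functional assay on HCT-116 cells (Homo sapiens) for cytotoxicity, read by MTT assay, with a stated time of 48 h (a higher number here means a weaker inhibitor, a lower number a stronger inhibitor), compound 1 (`COc1ccc2[nH]c(-c3ccccc3F)cc(=O)c2c1OC`) reaches only a limit (> 20000 nM). Compound 2 (`COc1ccc2[nH]c(-c3cccc(F)c3)cc(=O)c2c1OC`) gives 1200 nM and compound 3 (`COc1ccc2[nH]c(-c3ccccc3F)cc(=O)c2c1O`) gives 50 nM as the lowest number in the set. Two steps start from that limit: there is an at least 16-fold lower number from compound 1 to compound 2 (1.22 log units; beyond the scatter) with 3-fluorophenyl in place of 2-fluorophenyl, and there is an at least 400-fold lower number from compound 1 to compound 3 (2.60 log units; beyond the scatter) with hydrogen in place of methyl on an oxygen on an aromatic ring.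

Compound 4 (`COc1ccc2[nH]c(-c3ccc(F)cc3)cc(=O)c2c1O`) carries 4-fluorophenyl in place of 2-fluorophenyl on an aromatic carbon next to the ring nitrogen (4-fluorophenyl in place of 2-fluorophenyl on an aromatic carbon). Only the first step moves the fluorine, and it was measured with methyl still on the oxygen and to a different place, so it shows that such a move can be large but fixes no direction here. Compound 3 already sits low at 50 nM and a higher number therefore seems the likelier outcome. What is expected is a 4.0-fold higher number from compound 3 to compound 4 (0.60 log units; beyond the scatter) in this assay (an estimate, with real doubt about direction). For compound 4 the estimated value is 200 nM (expected range 25 nM to 2000 nM).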

Compound 4, half-maximal inhibitory concentration: 2400 nM
Beside the measured number, compound 4's estimate is 12-fold (1.08 log units) below it, outside the stated range (above it).
By their numbers in this assay, from the lowest: compound 3; then compounds 2 and 4 (each within the scatter of the next). At a limit, above all of these: compound 1.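

With hydrogen on the oxygen, the place of the fluorine on the phenyl ring decides much of the result in this assay: the change to 4-fluorophenyl gives a 48-fold higher number from compound 3 to compound 4 (1.68 log units; beyond the scatter). So the low number of compound 3 does not come from the free hydroxyl alone, since compound 4 keeps that hydroxyl and still loses most of the gain. The only earlier move of the fluorine ran the other way, an at least 16-fold lower number from compound 1 to compound 2 (1.22 log units; beyond the scatter), but it went to 3-fluorophenyl, started from a limit and had methyl on the oxygen, so it could not show this. Nothing given here explains why the 2-fluorophenyl group fares so much better.

Still open, as far as these compounds go, is how 3-fluorophenyl reads with hydrogen on that oxygen, and 4-fluorophenyl with methyl there. Also open, from the compounds shown here alone, is whether chlorine or an amine could take the fluorine's place on the phenyl ring.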